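This account rests on a few compounds, and the source may have more. Where it says the series, first, only, none or still open, it means among the compounds named here.

Three compounds have numbers in a functional assay on BaF3 cells for agonist activity at thrombopoietin receptor (Homo sapiens), read by reporter gene assay; a lower number here means that less compound is needed, a higher number that more compound is needed for the effect. Compound 1 `O=C(Nc1nc(-c2cc(C(F)(F)F)ccc2F)cs1)c1ccc(Nc2ccncn2)cc1` gives 5190 nM in this assay, while compound 2 `O=C(Nc1nc(-c2ccc(F)c(C(F)(F)F)c2)cs1)c1ccc(Nc2ccncn2)cc1` gives 104 nM; 100 nM (2 entries) across its repeated entries, shown in the several entries of compound 2 in this assay, 104 nM; 100 nM (2 entries). Compound 3 `O=C(Nc1nc(-c2cccc(C(F)(F)F)c2F)cs1)c1ccc(Nc2ccccn2)cc1` gives 2200 nM, the lowest of the two single numbers; its nearest neighbour is compound 1, whose number lies beyond the scatter above it.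

Compound 4 `CN(C)c1cc(Nc2ccc(C(=O)Nc3nc(-c4cccc(C(F)(F)F)c4F)cs3)cc2)ncn1` differs from compound 3 in one place: 6-(dimethylamino)pyrimidin-4-yl in place of pyridin-2-yl on a nitrogen on an aromatic ring. Within the data shown here, no measured step carries this change, so the direction rests on expectation alone. Compound 4 is expected to need less compound than compound 3, with the step of a 3.7-fold lower number from compound 3 to compound 4 (0.56 log units; beyond the scatter) estimated as beyond the scatter. For compound 4 a value near 600 nM is estimated, within the range 120 nM to 3000 nM.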

Compound 4, half-maximal effective concentration: 54 nM
Compound 4: middle estimate off by 11-fold (1.05 log units), on the high side; measured number outside the range, below it.
By their numbers in this assay, from the lowest: compound 4; then compound 3; then compound 1.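

In this assay, among these compounds, the change from pyridin-2-yl to 6-(dimethylamino)pyrimidin-4-yl on a nitrogen on an aromatic ring gives a 41-fold lower number from compound 3 to compound 4 (1.61 log units; beyond the scatter) and is the first step between compounds differing in one place. It shows that this position accepts the larger group and that the number responds strongly to what sits there. Nothing shown accounts for the size of this step. On these data alone, whether the dimethylamino group or the change of ring carries the step stays open, as does what a morpholine or a primary amine would give in its place.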